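From compound 3 to ring-bearing compound 4

The compounds below may be only part of what the source reports. "The series", "measured", "known", "first", "only" and "open" are said of these compounds alone.

Measured in an ADME assay on liver for metabolic stability, with Liver microsome (Homo sapiens) as the target, using microsomes; on this read-out lower numbers stand for slow clearance and higher numbers for fast clearance:
- compound 1 `CCN(CC)CCN(C)c1ccc(Nc2cc(NC3CC3)n3ncc(C#N)c3n2)cc1NC(C)=O`: 44 mL.min-1.g-1
- compound 2 `CC(=O)Nc1cc(Nc2cc(NC3CC3)n3ncc(C#N)c3n2)ccc1NCCCO`: 21 mL.min-1.g-1
- compound 3 `CCN(CCN)c1ccc(Nc2cc(NC3CC3)n3ncc(C#N)c3n2)cc1NC(C)=O`: 5 mL.min-1.g-1

Compound 3 stands lowest of the three. The steps down to it are a 4.2-fold lower number from compound 2 to compound 3 (0.62 log units; beyond the scatter) and an 8.8-fold lower number from compound 1 to compound 3 (0.94 log units; beyond the scatter), both beyond the scatter. Compound 4 `CC(=O)Nc1cc(Nc2cc(NC3CC3)n3ncc(C#N)c3n2)ccc1N1CCC[C@@H](N(C)C)C1` departs from compound 3 in one place: a group of 9 heavy atoms (7 carbon, 2 nitrogen; one six-membered non-aromatic ring with 1 hetero atom) in place of a group of 6 heavy atoms (4 carbon, 2 nitrogen; no ring), on an aromatic carbon. Among the compounds with values here, no measured compound carries this ring, so the guide is indirect. The entering group is closest in size to the (2-(diethylamino)ethyl)(methyl)amino group of compound 1, and the measured 8.8-fold lower number from compound 1 to compound 3 (0.94 log units; beyond the scatter), read in reverse, suggests a rise in this assay. The expected change, towards higher numbers, is a 5.6-fold higher number from compound 3 to compound 4 (0.75 log units; beyond the scatter). Compound 4 is expected at 28 mL.min-1.g-1, with an estimated range of 11 mL.min-1.g-1 to 65 mL.min-1.g-1.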

Compound 4, intrinsic clearance in microsomes: 19 mL.min-1.g-1
The estimate for compound 4 lay 1.5-fold (0.17 log units) above the measured number, within the range that was stated.
By their numbers in this assay, from the lowest: compound 3; then compounds 4 and 2 (each within the scatter of the next); then compound 1.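

In this assay, two groups with the same heavy-atom count do not give the same number at this position: the ring-bearing group gives a 2.3-fold lower number from compound 1 to compound 4 (0.36 log units; beyond the scatter) against the open-chain group. Even so, the ring does not match the low number of compound 3, with a 3.8-fold higher number from compound 3 to compound 4 (0.58 log units; beyond the scatter), while a 1.1-fold lower number from compound 2 to compound 4 (0.04 log units; within the scatter) leaves it level with the (3-hydroxypropyl)amino group. Nothing available explains these differences. The compounds shown leave open how the opposite stereocentre would read, and how a morpholine ring or a carboxylic acid at this position would compare.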